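The source may hold more compounds than are shown below. What is called first, only, known or untested is meant among the compounds shown, and "the series" means these compounds.

Measured so far in an assay on CHO cells for binding affinity to corticotropin-releasing factor receptor 1 (Homo sapiens); on this read-out higher numbers stand for weaker inhibition and lower numbers for stronger inhibition:
compound 1 `CCCN(CCC)c1cc(C)nc2c(-c3ccc(N(C)C)nc3)c(C)nn12`: 4.2 nM
compound 2 `CCCN(CCC)c1cc(C)nc2c(-c3ccc(C)nc3)c(C)nn12`: 21 nM

Going by the values given here, compound 2 holds the highest of the two numbers in this assay; its nearest neighbour is compound 1, from which it is separated by a 5.0-fold higher number from compound 1 to compound 2 (0.70 log units; beyond the scatter), the one change being methyl in place of dimethylamino on an aromatic carbon.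

Compound 3 `CCCN(CCC)c1cc(C)nc2c(-c3cnc(C)cc3C)c(C)nn12` differs from compound 2 by methyl in place of hydrogen on an aromatic carbon. The new methyl sits on an aromatic carbon of a six-membered aromatic ring with one nitrogen, ortho to a large group, meta to a methyl group and opposite the ring nitrogen; read one bond further out, 6-methylpyridin-3-yl becomes 4,6-dimethylpyridin-3-yl.

Among the compounds with values here, no measured step covers a methyl added at this position. The single step available, a 5.0-fold higher number from compound 1 to compound 2 (0.70 log units; beyond the scatter), concerns a different carbon and a different group exchange, so it only indicates the size of change this ring has shown. For the present change a small step, if any, is expected, leaning toward a higher number: a 1.4-fold higher number from compound 2 to compound 3 (0.15 log units; within the scatter). Compound 3 is therefore estimated at 30 nM in this assay, with a range from 10 nM to 100 nM.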

Compound 3, inhibition constant: 7.3 nM
Beside the measured number, compound 3's estimate is 4.1-fold (0.61 log units) above it; the measured number lies below the stated range.
By their numbers in this assay, from the lowest: compounds 1 and 3 (each within the scatter of the next); then compound 2.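

In this assay, a methyl on the aromatic carbon ortho to a large group, meta to a methyl group and opposite the ring nitrogen gives a 2.9-fold lower number from compound 2 to compound 3 (0.46 log units; beyond the scatter), so this position accepts the added group and the change from 6-methylpyridin-3-yl to 4,6-dimethylpyridin-3-yl moves the number beyond the scatter toward stronger inhibition. The exchange of 6-(dimethylamino)pyridin-3-yl for 4,6-dimethylpyridin-3-yl gives a 1.7-fold higher number from compound 1 to compound 3 (0.24 log units; within the scatter), which lies within the scatter, so in this small set the dimethylamino group is not the only substituent pattern that reaches this level of binding. Nothing available explains why the added methyl has this effect.

The compounds shown leave open whether a chlorine, a methoxy or an ethyl on this same carbon would shift the number as the methyl does, or whether the step is particular to methyl. They also leave open whether the same added methyl would give a comparable step on the 6-(dimethylamino)pyridin-3-yl ring of compound 1, as it has been read here only on the 6-methylpyridin-3-yl ring.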